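The source may hold more compounds than are shown below. What is called first, only, known or untested is meant among the compounds shown, and "the series" means these compounds.

Two compounds of the series have numbers in a functional assay on A549 cells (Homo sapiens) for antiproliferative activity, read by MTT assay, with a stated time of 48 h (a higher number here means a weaker inhibitor, a lower number a stronger inhibitor), so far. Compound 1 `N#Cc1ncn(-c2ccc(F)cc2)c1/N=C/c1ccc([N+](=O)[O-])cc1` gives 18100 nM in this assay. Compound 2 `N#Cc1ncn(-c2ccc(F)cc2)c1/N=C/c1ccc(O)cc1` gives 16300 nM in this assay. Within the data shown here, the single step between them, a 1.1-fold lower number from compound 1 to compound 2 (0.05 log units; within the scatter), lies within the scatter, so the two numbers are taken as the same; compound 2 therefore stands level with compound 1, with nothing to separate the pair.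

Compound 3 `COc1ccc(/C=N/c2c(C#N)ncn2-c2ccc(F)cc2)cc1` remains to be measured in this assay. It differs from compound 2 by methyl in place of hydrogen on an oxygen on an aromatic ring, which read one bond further out is hydroxy to methoxy, 4-hydroxyphenyl to 4-methoxyphenyl; the change sits on an oxygen on an aromatic ring whose other neighbour is an aromatic carbon.

Among the measured compounds shown here, only one measured step touches this position: a 1.1-fold lower number from compound 1 to compound 2 (0.05 log units; within the scatter), an exchange of the entire group at that place, which stayed within the scatter. With nothing else to go on, the expected step is a 1.1-fold lower number from compound 2 to compound 3 (0.04 log units; within the scatter), that is, none beyond the scatter. For compound 3 the estimate in this assay is 15000 nM, with a range from 7000 nM to 35000 nM.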

Compound 3, half-maximal inhibitory concentration: 17100 nM
Estimate against measurement, compound 3: 1.1-fold (0.06 log units) below; measured number inside the range.
By their numbers in this assay, from the lowest: compounds 2, 3 and 1 (each within the scatter of the next).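

In this assay, the change from 4-hydroxyphenyl to 4-methoxyphenyl gives a small step (a 1.0-fold higher number from compound 2 to compound 3 (0.02 log units; within the scatter)), so the hydrogen on this oxygen can be replaced by a methyl without a difference that can be told from the scatter. The earlier pair covered only an exchange of the entire group at this place; the new comparison with the nitro compound (a 1.1-fold lower number from compound 1 to compound 3 (0.02 log units; within the scatter)) adds a third group on the same aromatic carbon, and nitro, hydroxy and methoxy now all read as the same number within the scatter. No evidence at hand bears on why these groups read alike, so the result stays a bare observation.

From the compounds shown here alone, what remains open is whether any group at this place can separate itself from the others, as compounds 1, 2 and 3 give no step beyond the scatter and so offer no direction to follow. An amine or a carboxylic acid on the aromatic carbon, or a longer chain on the oxygen in place of the methyl, would test whether this tolerance holds beyond the three groups shown.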